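Swapping the Large Group on the Ring Nitrogen of Compound 3

A few compounds are considered here, and "the series" means these few. Any claim that something is new, unique, unknown or untested is made for them only; others in the source may bear on it.

In a functional assay on Ishikawa cells (Homo sapiens) for antiproliferative activity, read by CCK-8 assay, with a stated time of 48 h (a higher number here means a weaker inhibitor, a lower number a stronger inhibitor), compound 1 `O=C(/C=C/CNCCOc1ccc(Oc2c(-c3ccc(F)cc3)sc3cc(O)ccc23)cc1)N1CCCC1` gives 11300 nM. Compound 2 `C/C=C/C(=O)N1CC(Oc2ccc(Oc3c(-c4ccc(F)cc4)sc4cc(O)ccc34)cc2)C1` gives 9400 nM, and compound 3 `O=C(/C=C/CN1CC(Oc2ccc(Oc3c(-c4ccc(F)cc4)sc4cc(O)ccc34)cc2)C1)N1CCCC1` gives 9150 nM. These three values lie within the scatter of one another, so compound 3 stands level with both other compounds on the numbers shown.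

Compound 4 `C=CC(=O)N1CC(Oc2ccc(Oc3c(-c4ccc(F)cc4)sc4cc(O)ccc34)cc2)C1`, not yet measured, carries vinylcarbonyl in place of 3-((pyrrolidin-1-yl)carbonyl)prop-2-en-1-yl on an amine nitrogen in a ring, that of a four-membered non-aromatic ring with 1 nitrogen. The difference counts as follows: vinylcarbonyl in place of 3-((pyrrolidin-1-yl)carbonyl)prop-2-en-1-yl on an amine nitrogen in a ring.

Among the compounds with values here, one measured step bears on this change, and it falls at the same nitrogen. It is a 1.0-fold lower number from compound 2 to compound 3 (0.01 log units; within the scatter), in which the same large group took the place of (prop-1-en-1-yl)carbonyl. Within the data shown here, no measured compound carries vinylcarbonyl itself, so this step is only a near guide. Since exchanging the large group for a small acyl group left the number unmoved there, no step beyond the scatter is expected in this assay, and no direction is favoured. Compound 4 is estimated at 8500 nM, with an expected range of 4500 nM to 14000 nM. That estimate means an expected 1.1-fold lower number from compound 3 to compound 4 (0.03 log units; within the scatter).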

Compound 4, half-maximal inhibitory concentration: 12300 nM
For compound 4 the middle estimate is 1.4-fold (0.16 log units) below the measured one; the range from low to high includes it.
By their numbers in this assay, from the lowest: compounds 3, 2, 1 and 4 (each within the scatter of the next).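

In this assay, replacing the 3-((pyrrolidin-1-yl)carbonyl)prop-2-en-1-yl group, which carries a ring, with the ring-free vinylcarbonyl on the amine nitrogen of the four-membered ring gives a 1.3-fold higher number from compound 3 to compound 4 (0.13 log units; within the scatter). Changing the small acyl group itself, with vinyl in place of prop-1-en-1-yl on a carbonyl carbon, gives a 1.3-fold higher number from compound 2 to compound 4 (0.12 log units; within the scatter). With the earlier step, all three groups compared at this nitrogen now lie within the scatter of one another, so neither the large group nor either of the small acyl groups separates from the others in this antiproliferative read-out, and the removal of the methyl-bearing end of the acyl group leaves the comparison equally level.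

As far as these compounds go, whether a quite different substituent on this nitrogen, such as a simple alkyl chain, a sulfonyl group or a carboxylic acid, would produce a step beyond the scatter remains open. The data at hand offer no information on why these three groups fall level.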